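Swapping the ring group on a carbonyl carbon

This account rests on a few compounds, and the source may have more. Where it says the series, first, only, none or still open, it means among the compounds named here.

In a functional assay on DLD-1 cells (Homo sapiens) for inhibition, read by luminescence, with a stated time of 3 days (on this read-out lower numbers stand for stronger inhibition of growth and higher numbers for weaker inhibition of growth), compound 1 `CC(C)C1=C(C(=O)N2[C@H](C)CC[C@H]2C(=O)N2CCN(C)CC2)SC2=N[C@@](C)(c3ccc(Cl)cc3)[C@@H](c3ccc(Cl)cc3)N21` gives 9000 nM, compound 2 `CC(=O)N1CCN(C(=O)[C@@H]2CC[C@@H](C)N2C(=O)C2=C(C(C)C)N3C(=N[C@@](C)(c4ccc(Cl)cc4)[C@H]3c3ccc(Cl)cc3)S2)C[C@H]1C` gives 11000 nM and compound 3 `CC(=O)N1CCN(C(=O)[C@@H]2CC[C@@H](C)N2C(=O)C2=C(C(C)C)N3C(=N[C@@](C)(c4ccc(Cl)cc4)[C@H]3c3ccc(Cl)cc3)S2)C[C@@H]1C` gives 5200 nM. Compound 3 therefore lies within the scatter of compound 1, but clear of compound 2, with a 2.1-fold lower number from compound 2 to compound 3 (0.33 log units; beyond the scatter). That modest gap comes with the fact that compounds 2 and 3 differ only in the configuration as drawn.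

Compound 4 `CC(C)C1=C(C(=O)N2[C@H](C)CC[C@H]2C(=O)N2CCN(C)C(C)(C)C2)SC2=N[C@@](C)(c3ccc(Cl)cc3)[C@@H](c3ccc(Cl)cc3)N21` carries a group of 9 heavy atoms (7 carbon, 2 nitrogen; one six-membered non-aromatic ring with 2 hetero atoms) in place of a group of 10 heavy atoms (7 carbon, 2 nitrogen, 1 oxygen; one six-membered non-aromatic ring with 2 hetero atoms), on a carbonyl carbon. Both groups hold one six-membered non-aromatic ring with 2 hetero atoms, and the swap happens on a carbonyl carbon.

Two measured steps changed the group at this same place: a 1.2-fold higher number from compound 1 to compound 2 (0.09 log units; within the scatter) and a 1.7-fold lower number from compound 1 to compound 3 (0.24 log units; within the scatter). Neither left the scatter, and the configuration step above was only just beyond it. In this assay no step beyond the scatter is therefore expected, given how little compound 2 at 11000 nM and compound 3 at 5200 nM moved from compound 1.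

The expected size of the change is a 1.3-fold higher number from compound 3 to compound 4 (0.13 log units; within the scatter). For compound 4 the estimated value is 7000 nM, with an expected range from 3000 nM to 16000 nM.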

Compound 4, concentration for 50% growth inhibition in the DLD-1 assay: 6300 nM
For compound 4 the middle estimate is 1.1-fold (0.05 log units) above the measured one; measured number inside the range.
By their numbers in the DLD-1 assay, from the lowest: compounds 3, 4, 1 and 2 (each within the scatter of the next, the first and the last beyond it).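

In the DLD-1 assay, the group of 9 heavy atoms on this carbonyl carbon stays level with all the earlier groups, with a 1.2-fold higher number from compound 3 to compound 4 (0.08 log units; within the scatter), a 1.7-fold lower number from compound 2 to compound 4 (0.24 log units; within the scatter) and a 1.4-fold lower number from compound 1 to compound 4 (0.15 log units; within the scatter). A ring group holding only carbon and nitrogen thus sits within the scatter of both the group of 7 heavy atoms and the two groups of 10 heavy atoms, so this growth read-out tolerates all of these swaps at this place. The swap from compound 3 to compound 4 does register in a physicochemical assay for solubility, read by HPLC, in phosphate buffer, at pH 6.8 (a higher number here means a more soluble compound, a lower number a less soluble compound), where compound 3 gives 75 ug/mL and compound 4 gives 30 ug/mL, and it goes with lower solubility: the measured solubility of compound 3, 75 ug/mL, and of compound 4, 30 ug/mL, a 2.5-fold lower number (0.40 log units; beyond the scatter)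

Every group shown holds one six-membered non-aromatic ring with 2 hetero atoms, so the effect of an open-chain amine or a carboxylic acid on this carbonyl carbon stays open. One pair in the physicochemical assay also cannot tell whether solubility would shift the same way with other groups here.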